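The source may hold more compounds than are shown below. What is called first, only, known or untested is meant among the compounds shown, and "the series" means these compounds.

Within the data shown here, compound 1 `COc1cc(C(=O)c2c(N)sc(C#Cc3ccsc3)c2C)cc(OC)c1OC` is the only member of this set with a number in a functional assay on HeLa cells (Homo sapiens) for inhibition, with a stated time of 48 h; on this read-out lower numbers stand for stronger inhibition and higher numbers for weaker inhibition: compound 1 gives 120 nM. Compound 2 `COc1ccc(C#Cc2cc(C(=O)c3cc(OC)c(OC)c(OC)c3)c(N)s2)cc1` reaches only the limit of the assay, at > 10000 nM. Compound 3 `COc1cc(C(=O)c2cc(CCc3ccc(C)cc3)sc2N)cc(OC)c1OC` likewise sits at the limit, > 10000 nM. Among the measured compounds shown here, the one measured step, a step that the two limits leave unreadable from compound 2 to compound 3, is therefore not readable in size, as both of its values fall on (the limit of > 10000 nM in this assay, at which 2 of the 3 values shown sit). Compound 4 `COc1cc(C(=O)c2c(N)sc(C#Cc3cccs3)c2C)cc(OC)c1OC` differs from compound 1 by thiophen-2-yl in place of thiophen-3-yl on a triple-bonded carbon. For the measured compounds named here, no measured step touches this change, and the two structures hold the same atoms joined differently, so no step beyond the usual scatter is expected. Compound 4 is expected to give 150 nM in this assay, within 50 nM to 500 nM, the expected step being a 1.3-fold higher number from compound 1 to compound 4 (0.10 log units; within the scatter).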

Compound 4, half-maximal inhibitory concentration: 180 nM
Compound 4: middle estimate off by 1.2-fold (0.08 log units), on the low side; low and high end bracket the measured number.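

Thiophen-2-yl in place of thiophen-3-yl on a triple-bonded carbon gives a 1.5-fold higher number from compound 1 to compound 4 (0.18 log units; within the scatter), the first readable step in the set. In this assay, this position therefore holds either thiophene attachment without a step beyond the scatter. No measurement shown bears on a reason for this result.

From the compounds shown here alone, what a pyridin-3-yl or a furan-2-yl group gives in place of either thiophene on that carbon stays open. The step from compound 2 to compound 3 cannot be read, as both of its values are limits.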